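Replacing an Aryl Amide Group with an Aminoalkyl Chain

A few compounds are considered here, and "the series" means these few. Any claim that something is new, unique, unknown or untested is made for them only; others in the source may bear on it.

Measured in a functional assay on HOS cells (Homo sapiens) for inhibition, read by MTT assay, with a stated time of 72 h (on this read-out higher numbers stand for weaker inhibition and lower numbers for stronger inhibition), were these compounds
Compound 1 `COc1ccccc1NC(=O)CCC(=O)OCCCCCCSc1ccc([N+](=O)[O-])c2nonc12` gives 2850 nM
Compound 2 `O=C(CCC(=O)OCCCCCCSc1ccc([N+](=O)[O-])c2nonc12)Nc1ccc(F)cc1` gives 2080 nM
Compound 3 `Cc1ccc(NC(=O)CCC(=O)OCCCCCCSc2ccc([N+](=O)[O-])c3nonc23)cc1` gives 3340 nM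

Compound 3 lies within the scatter of both others, through a 1.2-fold higher number from compound 1 to compound 3 (0.07 log units; within the scatter) and a 1.6-fold higher number from compound 2 to compound 3 (0.21 log units; within the scatter), and the remaining pair shows a 1.4-fold lower number from compound 1 to compound 2 (0.14 log units; within the scatter) too. Compound 4 `CN(C)CCCNC(=O)CCC(=O)OCCCCCCSc1ccc([N+](=O)[O-])c2nonc12` carries 3-(dimethylamino)propyl in place of 4-methylphenyl on an amide-type nitrogen, (3-(dimethylamino)propyl in place of 4-methylphenyl on an amide-type nitrogen). The measured steps bear on this only indirectly, since each exchanges one phenyl group for another and none tests a chain without a ring. No step beyond the scatter is therefore expected in this assay, and no direction can be favoured with confidence. The estimated change is a 1.3-fold lower number from compound 3 to compound 4 (0.13 log units; within the scatter), with wide uncertainty. For compound 4 the expected value is 2500 nM, within an estimated range of 700 nM to 8000 nM.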

Compound 4, half-maximal inhibitory concentration: 1850 nM
Compound 4: middle estimate off by 1.4-fold (0.13 log units), on the high side; low and high end bracket the measured number.
By their numbers in this assay, from the lowest: compounds 4, 2, 1 and 3 (each within the scatter of the next).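

In this assay the ring-free 3-(dimethylamino)propyl on the amide-type nitrogen stays within the scatter of all three aryl compounds (a 1.8-fold lower number from compound 3 to compound 4 (0.26 log units; within the scatter)) (a 1.1-fold lower number from compound 2 to compound 4 (0.05 log units; within the scatter)) (a 1.5-fold lower number from compound 1 to compound 4 (0.19 log units; within the scatter)). Among these four compounds, then, an aromatic ring at this position is not needed to keep the number in the same range. Nothing measured here accounts for this result. What the compounds shown leave open is whether a plain propyl chain, a longer aminoalkyl chain or a carboxylic acid in place of the dimethylamino group would stay in that range.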